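The source may hold more compounds than are shown below. What is called first, only, known or untested is meant among the compounds shown, and "the series" means these compounds.

Compound 2, `C[C@@H](NC(=O)Nc1ccc(Br)cc1)c1ccccc1`, gives 95% in an ADME assay on the whole organism with Oryza sativa as the target, tested at 1 uM; on this read-out higher numbers stand for a weaker effect at the one concentration tested and lower numbers for a stronger effect. For the measured compounds named here, its only measured companion is compound 1, `CCOC(=O)c1ccc(NC(=O)N[C@H](C)c2ccccc2)cc1`, which in this assay gives 100%; the two numbers lie within the scatter of one another, so neither can be ranked against the other. Compound 3, `C[C@@H](NC(=O)Nc1ccc(I)cc1)c1ccccc1`, has not yet been measured in this assay. It differs from compound 2 by iodo in place of bromo on an aromatic carbon. Going by the values given here, the one measured step that speaks to a swap of a group on this aromatic carbon is a number 5 percentage points lower from compound 1 to compound 2 (within the scatter), and that swap exchanged groups far more unlike each other than bromo and iodo are. On that basis no step beyond the scatter is expected here, so the estimated shift is no change at the digits printed from compound 2 to compound 3 (within the scatter). Compound 3 is therefore expected to give about 95% in this assay, within a range from 80% to 100%, pending the actual measurement.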

Compound 3, a percentage reported as activity, at one concentration (the size of the read-out at that concentration, not a potency): 91%
For compound 3 the middle estimate is 4 percentage points above the measured one; measured number inside the range.
By their numbers in this assay, from the lowest: compounds 3, 2 and 1 (each within the scatter of the next).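

Iodo in place of bromo gives a number 4 percentage points lower from compound 2 to compound 3 (within the scatter) in this assay and iodo in place of ethoxycarbonyl gives a number 9 percentage points lower from compound 1 to compound 3 (within the scatter) on the same aromatic carbon, para to a large group. This position now carries three groups whose numbers cannot be told apart on this read-out, and the heavier of the two halogens does not separate itself from either of the others. Nothing measured on hand offers an explanation for this result.

As far as these compounds go, whether a group of another kind at this position, such as an amine or a carboxylic acid, would produce a step beyond the scatter remains open. The compounds shown also leave open whether a change elsewhere on the shared core would move the number at all.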